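This account rests on a few compounds, and the source may have more. Where it says the series, first, only, none or still open, it means among the compounds named here.

In a functional assay on A-375 cells (Homo sapiens) for antiproliferative activity, read by CCK-8 assay, with a stated time of 72 h, tested at 2 uM (on this read-out lower numbers stand for a weaker effect and higher numbers for a stronger effect at the one concentration tested), compound 1, whose structure is `Nc1ccccc1NC(=O)c1ccc(CSC(=S)N2CCN(C3CCCCC3)CC2)cc1`, gives 31.7%. Going by the values given here, of the three numbers measured so far, this is the highest. Compound 2, with the structure `Nc1ccccc1NC(=O)c1ccc(CSC(=S)N2CCc3ccc([N+](=O)[O-])cc32)cc1`, gives 22.1% in this assay, a number that lies within the usual scatter of the value of compound 1. Compound 3, the structure `Nc1ccccc1NC(=O)c1ccc(CSC(=S)N2CCN(C(c3ccccc3)c3ccccc3)CC2)cc1`, gives 8.7% in this assay, and its gap to compound 1 lies beyond the scatter. None of these three compounds differs from another in only one place, so each number stands by itself.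

Compound 4 has the structure `Nc1ccccc1NC(=O)c1ccc(CSC(=S)N2CCN(c3ccncc3)CC2)cc1` and has not yet been measured in this assay. It is related to compound 1 by a single change: pyridin-4-yl in place of cyclohexyl on an amine nitrogen in a ring. The rest of the molecule is unchanged.

Among the compounds with values here, no measured pair shows what an exchange on this amine nitrogen in a ring does to the read-out. Compound 3 also carries another group at that nitrogen and sits well under compound 1, but it is not a single-place neighbour of compound 1, so its number gives only a hint. On that basis the step of a number 6.7 percentage points lower from compound 1 to compound 4 (within the scatter) is expected to be small, if anything slightly downward, and not clearly beyond the scatter. Compound 4 is expected to give about 25% in this assay, with a likely range from 8% to 42%.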

Compound 4, a percentage reported as inhibition, at one concentration (the size of the read-out at that concentration, not a potency): 85.7%
The estimate for compound 4 lay 60.7 percentage points below the measured number; the whole stated range lies below it.
By their numbers in this assay, from the lowest: compound 3; then compounds 2 and 1 (each within the scatter of the next); then compound 4.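

The exchange of cyclohexyl for pyridin-4-yl on this amine nitrogen in a ring brings a number 54 percentage points higher from compound 1 to compound 4 (beyond the scatter) in this assay, the first direct sign that the read-out responds strongly to the group at this place. The two groups have the same count of heavy atoms and both form a six-membered ring, so that count does not separate them; they differ in that the entering ring is aromatic, holds a nitrogen and counts as a hydrogen-bond acceptor. No measurement available here bears on why the read-out rises or on which of these differences matters.

The compounds shown leave open whether the aromatic ring alone would carry the step, which phenyl at this nitrogen could separate from the contribution of the ring nitrogen, and whether pyridin-3-yl or pyridin-2-yl would behave like pyridin-4-yl. They also leave open how this single step translates into potency, since the read-out gives the size of the effect at one concentration only.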